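Working notes: the step from compound 3 to compound 4

The compounds below may be only part of what the source reports. "The series", "measured", "known", "first", "only" and "open" are said of these compounds alone.

Measured in a functional assay on DU-145 cells (Homo sapiens) for inhibition, read by trypan blue exclusion, with a stated time of 96 h; on this read-out higher numbers stand for weaker inhibition of growth and lower numbers for stronger inhibition of growth:
- compound 1 `Cc1ccc(S/C(=C/c2sccc2C)C(=O)c2ccc(Br)cc2)cc1`: 50000 nM
- compound 2 `Cc1ccc(S/C(=C/c2cc(Cl)cc(Cl)c2Cl)C(=O)c2ccc(Cl)cc2)cc1`: 50000 nM
- compound 3 `Cc1ccc(S/C(=C/c2sccc2C)C(=O)c2ccc(Cl)cc2)cc1`: 50000 nM

Compound 1 and compound 2 stand level with compound 3 at 50000 nM. The next structure is compound 4 `COc1ccc(/C=C(/Sc2ccc(C)cc2)C(=O)c2ccc(Cl)cc2)cc1O`, changed on a double-bonded chain carbon bound to a double-bonded chain carbon: 3-hydroxy-4-methoxyphenyl in place of 3-methylthiophen-2-yl on a double-bonded chain carbon bound to a double-bonded chain carbon.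

Within the data shown here, two measured steps bear on this. The closer one, no change at the digits printed from compound 2 to compound 3 (within the scatter), exchanges groups at that same place. The other, no change at the digits printed from compound 1 to compound 3 (within the scatter), exchanges chloro and bromo on an aromatic carbon elsewhere. Among the measured compounds shown here, neither step gives a direction, and 3-hydroxy-4-methoxyphenyl appears in no measured compound, so the data set no firm size for the new step. A moderate move toward stronger inhibition of growth in this assay is expected, though no change remains possible.

The estimated change is a 5.0-fold lower number from compound 3 to compound 4 (0.70 log units; beyond the scatter). Compound 4 is expected at 10000 nM, with an estimated range of 800 nM to 50000 nM.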

Compound 4, concentration for 50% growth inhibition: 1000 nM
For compound 4 the middle estimate is 10-fold (1.00 log units) above the measured one; the measured number falls inside the stated range.
By their numbers in this assay, from the lowest: compound 4; then compounds 1, 2 and 3 (each within the scatter of the next).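

In this assay the place on a double-bonded chain carbon bound to a double-bonded chain carbon proves able to move the number, with a 50-fold lower number from compound 3 to compound 4 (1.70 log units; beyond the scatter) for 3-hydroxy-4-methoxyphenyl in place of 3-methylthiophen-2-yl and a 50-fold lower number from compound 2 to compound 4 (1.70 log units; beyond the scatter) for the same group in place of 2,3,5-trichlorophenyl. The earlier exchange at this place showed no change at the digits printed from compound 2 to compound 3 (within the scatter) and so gave no sign of this sensitivity, and the gain belongs to the entering group rather than to the place being changed at all. Nothing available accounts for the gain.

The compounds shown do not separate the contribution of the hydroxy from that of the methoxy within the entering group, nor show whether an amine or a carboxylic acid could stand in place of the hydroxy. From the compounds shown here alone, whether bromo in place of chloro on an aromatic carbon still makes no difference with 3-hydroxy-4-methoxyphenyl present also remains open.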